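Hydrogen for methoxy on a silyl-protected cyclopentenone

The compounds below may be only part of what the source reports. "The series", "measured", "known", "first", "only" and "open" are said of these compounds alone.

Measured compounds:
- compound 1, `COc1ccc(C2=C(c3cc(OC)c(OC)c(OC)c3)C(=O)C(OC(C)=O)C2)cc1F`: 16 ug/mL
- compound 2, `COc1ccc(C2=C(c3cc(OC)c(OC)c(OC)c3)C(=O)CC2O[SiH2]C(C)(C)C)cc1OC`: > 100 ug/mL
- compound 3, `COc1ccc(C2=C(c3cc(OC)c(OC)c(OC)c3)C(=O)C(O)C2)cc1NC(=O)c1ccccc1`: > 100 ug/mL

In an ADME assay on DU-145 cells (Homo sapiens) for cytotoxicity, read by MTT assay, with a stated time of 72 h (a lower number here means a stronger inhibitor, a higher number a weaker inhibitor), compound 1 gives 16 ug/mL. Compound 2 reaches only a limit in this assay, > 100 ug/mL. Compound 3 likewise reaches only a limit, > 100 ug/mL. Among the measured compounds shown here, compound 2 thus stands at the limit of > 100 ug/mL in this assay, at which 2 of the 3 values shown sit, with no number of its own, so no step can be measured from it.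

Compound 4, `COc1ccc(C2=C(c3cc(OC)c(OC)c(OC)c3)C(=O)CC2O[SiH2]C(C)(C)C)cc1`, has not yet been measured in this assay. It differs from compound 2 by hydrogen in place of methoxy on an aromatic carbon. With compound 2 known only as a limit, the step from compound 2 to compound 4 cannot be sized from the data; the account expects compound 4 to remain near that limit, with no change beyond the scatter, and the step is estimated as an at least 1.1-fold lower number from compound 2 to compound 4 (0.04 log units; that floor lies within the scatter). For compound 4 the estimate in this assay is 90 ug/mL, expected to fall between 30 ug/mL and 300 ug/mL.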

Compound 4, half-maximal inhibitory concentration: > 100 ug/mL
Compound 4 gave a limit, no number; the forecaster's own chance of this, stated with the estimate: 60%; at least 1.1-fold (0.04 log units) between middle value and limit.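

Compound 2 and compound 4 both give only a limit, so no step can be read between them: the limit of > 100 ug/mL in this assay, at which 3 of the 4 values shown sit.

The compounds shown leave open whether hydrogen in place of methoxy on an aromatic carbon changes the read-out at all.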